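From pyridin-3-yl to 6-aminopyridin-3-yl on compound 3

The source may report more compounds than this note shows. Statements on the series, on what has been measured and on what is new or still open speak of the compounds shown alone.

In a functional assay on COR-L23 cells (Homo sapiens) for antiproliferative activity, read by CellTiter-Glo, with a stated time of 72 h (on this read-out higher numbers stand for weaker inhibition and lower numbers for stronger inhibition), compound 1 (`C[C@H](NC(=O)c1ncccn1)c1ccc(NC(=O)N2CC(c3cccnc3)C2)cc1`) gives 130 nM, compound 2 (`C[C@H](NC(=O)C1CCOCC1)c1ccc(NC(=O)N2CC(c3cccnc3)C2)cc1`) gives 58 nM and compound 3 (`C[C@H](NC(=O)[C@@H]1CCCN1C)c1ccc(NC(=O)N2CC(c3cccnc3)C2)cc1`) gives 38 nM. Compound 3 thus stands level with compound 2 and clear of compound 1. Compound 4 (`C[C@H](NC(=O)[C@@H]1CCCN1C)c1ccc(NC(=O)N2CC(c3ccc(N)nc3)C2)cc1`) has amino in place of hydrogen on an aromatic carbon, turning pyridin-3-yl into 6-aminopyridin-3-yl: amino in place of hydrogen on an aromatic carbon. The measured steps, a 2.2-fold lower number from compound 1 to compound 2 (0.35 log units; beyond the scatter), a 3.4-fold lower number from compound 1 to compound 3 (0.53 log units; beyond the scatter) and a 1.5-fold lower number from compound 2 to compound 3 (0.18 log units; within the scatter), all change the group on the carbonyl carbon, so none bears directly on this change. No step beyond the scatter is therefore expected, in either direction. The expected step is a 1.3-fold higher number from compound 3 to compound 4 (0.12 log units; within the scatter). Compound 4 is estimated at 50 nM, within a range of 10 nM to 250 nM.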

Compound 4, half-maximal inhibitory concentration: 41 nM
Compound 4: middle estimate off by 1.2-fold (0.09 log units), on the high side; the range from low to high includes it.
By their numbers in this assay, from the lowest: compounds 3, 4 and 2 (each within the scatter of the next); then compound 1.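

Amino in place of hydrogen on this aromatic carbon, next to the ring nitrogen and para to a large group, gives a 1.1-fold higher number from compound 3 to compound 4 (0.03 log units; within the scatter) in this assay. Within the data shown here, the earlier compounds differed only in the group on the carbonyl carbon, so this is the first reading at the pyridin-3-yl end, and the added amino costs nothing beyond the scatter. Nothing available explains this result. From the compounds shown here alone, whether a dimethylamino or methoxy group would be accepted at this carbon stays open, as does whether the 6-aminopyridin-3-yl group behaves alike with oxan-4-yl on the carbonyl carbon.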